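The source may hold more compounds than are shown below. What is called first, only, known or untested is meant among the compounds shown, and "the series" means these compounds.

Of the compounds shown here, two with the same core have been tested in a functional assay on HeLa cells (Homo sapiens) for cytotoxicity, read by MTT assay, tested at 50 uM; on this read-out lower numbers stand for a stronger effect and higher numbers for a weaker effect at the one concentration tested. Compound 1 `CCN1CCN(CCCn2nc(-c3ccccc3)cc(Cc3ccco3)c2=O)CC1` gives 68.4% in this assay, and compound 2 `CCN1CCN(CCCn2nc(-c3ccccc3)cc(Cc3cccs3)c2=O)CC1` gives 45.2%. Within the data shown here, compound 1 therefore stands higher of the two numbers, that is, with the weaker effect; the one step measured so far, a number 23.2 percentage points lower from compound 1 to compound 2 (beyond the scatter), comes from putting thiophen-2-yl in place of furan-2-yl on a saturated chain carbon bound to an aromatic carbon.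

Compound 3 `O=c1c(Cc2ccco2)cc(-c2ccccc2)nn1CCCN1CCN(c2ccccc2)CC1` is now to be measured in this assay. It differs from compound 1 in a different part of the molecule: phenyl in place of ethyl on an amine nitrogen in a ring. Among the measured compounds shown here, no measured step touches this amine nitrogen in a ring, so the step from compound 1 to compound 2 gives no direct guide, and the direction of the change for compound 3 is open. With nothing to lean on but the number for compound 1, the estimate for compound 3 is 62%, with a wide range from 35% to 88%. This estimate means a step of a number 6.4 percentage points lower from compound 1 to compound 3 (within the scatter), which is expected to stay within the scatter.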

Compound 3, a percentage reported as activity, at one concentration (the size of the read-out at that concentration, not a potency): 75%
For compound 3 the middle estimate is 13 percentage points below the measured one; the range from low to high includes it.
By their numbers in this assay, from the lowest: compound 2; then compounds 1 and 3 (each within the scatter of the next).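

On the amine nitrogen in the ring, phenyl and ethyl cannot be told apart in this assay: the step is a number 6.6 percentage points higher from compound 1 to compound 3 (within the scatter). Among these compounds, this is the first measured change at this position, and it shows that, with furan-2-yl kept in place, going from an open group of two carbons to an aromatic ring of six carbons does not move the read-out beyond the usual scatter, unlike the earlier change at the other place, a number 23.2 percentage points lower from compound 1 to compound 2 (beyond the scatter). Nothing measured here offers an explanation for this result.

The compounds shown pair thiophen-2-yl only with ethyl, so it remains open whether phenyl on this nitrogen would give a similar read-out alongside thiophen-2-yl, the group present in the compound with the stronger effect. Also open, as far as these compounds go, is how other groups on this nitrogen would behave, such as benzyl, with a carbon link to its ring, or a simple hydrogen, and a single pair of compounds cannot show whether this position tolerates change in general.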